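Aryl replacement on the shared core: outlook for compound 4

This account rests on a few compounds, and the source may have more. Where it says the series, first, only, none or still open, it means among the compounds named here.

Measured in a functional assay on MKN-45 cells (Homo sapiens) for inhibition, with a stated time of 72 h; on this read-out higher numbers stand for weaker inhibition and lower numbers for stronger inhibition:
compound 1 `COc1ccc(S(=O)(=O)N2CCc3cccc(-c4ccc(C#N)cc4)c32)cc1`: 17.2 nM
compound 2 `COc1ccc(S(=O)(=O)N2CCc3cccc(-c4ccc(O)cc4)c32)cc1`: 82.6 nM
compound 3 `COc1ccc(S(=O)(=O)N2CCc3cccc(-c4ccc(F)c(F)c4)c32)cc1`: 55.5 nM

Compound 3 stands second highest of the three numbers; the nearest of the other two lies a 1.5-fold lower number from compound 2 to compound 3 (0.17 log units; within the scatter), the furthest a 3.2-fold higher number from compound 1 to compound 3 (0.51 log units; beyond the scatter). Compound 4 `COc1ccc(S(=O)(=O)N2CCc3cccc(-c4ccc(N(C)C)cc4)c32)cc1` differs from compound 3 in one place: 4-(dimethylamino)phenyl in place of 3,4-difluorophenyl on an aromatic carbon. Among the compounds with values here, no measured step introduces a dimethylamino group, so only the aryl swaps on the same carbon bear on it: a 4.8-fold higher number from compound 1 to compound 2 (0.68 log units; beyond the scatter) and a 3.2-fold higher number from compound 1 to compound 3 (0.51 log units; beyond the scatter), both modest, and a 1.5-fold lower number from compound 2 to compound 3 (0.17 log units; within the scatter), within the scatter. Compound 4 is therefore expected to move little in this assay, a 1.1-fold higher number from compound 3 to compound 4 (0.03 log units; within the scatter), with wide uncertainty. The estimate for compound 4 is 60 nM, range 18 nM to 200 nM.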

Compound 4, half-maximal inhibitory concentration: 237 nM
Compound 4: middle estimate off by 4.0-fold (0.60 log units), on the low side; measured number above the stated range.
By their numbers in this assay, from the lowest: compound 1; then compounds 3 and 2 (each within the scatter of the next); then compound 4.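

In this assay, 4-(dimethylamino)phenyl on this aromatic carbon gives the highest number of the four compounds, with every step to it beyond the scatter (a 4.3-fold higher number from compound 3 to compound 4 (0.63 log units; beyond the scatter); a 2.9-fold higher number from compound 2 to compound 4 (0.46 log units; beyond the scatter)). Within the data shown here, the step from the 4-cyanophenyl compound is the first large one at this position (a 14-fold higher number from compound 1 to compound 4 (1.14 log units; beyond the scatter)), so the aryl group here can shift the number further than compounds 1 to 3 showed. No measurement shown accounts for this shift.

Open, from the compounds shown here alone, is whether a primary amine or a carboxylic acid on the same aryl ring would fall nearer compound 1 or compound 4.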